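Adding a Third Methoxy to a Styryl Pyranone Core

The source may report more compounds than this note shows. Statements on the series, on what has been measured and on what is new or still open speak of the compounds shown alone.

Of the compounds shown here, three sharing one core have been measured in a functional assay on NCI-H460 cells (Homo sapiens) for inhibition, read by sulforhodamine B assay, with a stated time of 48 h; a higher number here means a weaker inhibitor of growth, a lower number a stronger inhibitor of growth. Compound 1 `O=C1C=COC(/C=C/c2ccc(C(F)(F)F)cc2)C1` gives 95.6 uM. Compound 2 `COc1ccc(/C=C/C2CC(=O)C=CO2)cc1` gives 149 uM, and the step of a 1.6-fold higher number from compound 1 to compound 2 (0.19 log units; within the scatter) is small. Compound 3 `COc1ccc(/C=C/C2CC(=O)C=CO2)cc1OC` gives 89.6 uM, which is the lowest of the three numbers, although its gap to compound 1 and to compound 2 lies within the usual scatter, so no order among them can be claimed.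

Compound 4 `COc1cc(/C=C/C2CC(=O)C=CO2)cc(OC)c1OC` is not yet measured in this assay. It differs from compound 3 in one place: methoxy in place of hydrogen on an aromatic carbon.

Going by the values given here, the one measured step that bears on this change is a 1.7-fold lower number from compound 2 to compound 3 (0.22 log units; within the scatter), where the same kind of replacement, methoxy in place of hydrogen on an aromatic carbon, gave a number that did not move beyond the scatter. Among the compounds with values here, with only that step to go on, no step beyond the scatter is expected from compound 3 to compound 4 in this assay; if anything, a slight lowering is expected, in line with a 1.7-fold lower number from compound 2 to compound 3 (0.22 log units; within the scatter). Compound 4 is therefore estimated to give 75 uM in this assay, within a range from 35 uM to 160 uM, corresponding to an expected step of a 1.2-fold lower number from compound 3 to compound 4 (0.08 log units; within the scatter).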

Compound 4, concentration for growth inhibition (reported as GI): 127 uM
Compound 4: middle estimate off by 1.7-fold (0.23 log units), on the low side, within the range that was stated.
By their numbers in this assay, from the lowest: compounds 3, 1, 4 and 2 (each within the scatter of the next).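

In this assay, placing a methoxy on this aromatic carbon, ortho to a methoxy group and meta to both a group of 9 heavy atoms and a second methoxy group, gives a 1.4-fold higher number from compound 3 to compound 4 (0.15 log units; within the scatter) and so produces no step beyond the scatter at this crowded position. Alongside a 1.7-fold lower number from compound 2 to compound 3 (0.22 log units; within the scatter), this makes two replacements of the same kind on the aromatic ring, neither beyond the scatter and with their printed numbers running in opposite directions, so compound 2, compound 3 and compound 4 show no trend with the number of methoxy groups. Nothing given here accounts for where the number of compound 4 lies.

The compounds shown leave open whether an amine or a carboxylic acid on this same aromatic carbon, or a longer chain such as ethoxy in place of the methoxy, would move the number beyond the scatter. They also leave open whether any change on the aromatic ring can do so, since each of the four compounds stands within the scatter of the next.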